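The source may hold more compounds than are shown below. What is called first, only, known or untested is meant among the compounds shown, and "the series" means these compounds.

Measured so far:
compound 1 `COc1ccc(-c2cc(-c3ccc(S(N)(=O)=O)cc3)cnc2N)cn1`: > 100 ug/mL
compound 2 `COc1ccc(-c2cc(-c3ccc(C(=O)O)cc3)cnc2N)cn1`: 12.5 ug/mL
compound 3 `COc1ccc(-c2cc(-c3ccc(C(N)=O)cc3)cnc2N)cn1`: > 100 ug/mL

In a physicochemical assay for solubility, read by nephelometry, measured as kinetic solubility, at pH 2 (on this read-out higher numbers stand for higher solubility and lower numbers for lower solubility), compound 3 gives > 100 ug/mL, which is a limit of the assay and not a number. Compound 1 likewise returns only a limit, > 100 ug/mL. Among the compounds with values here, compound 2 is the one plain number of the three, giving 12.5 ug/mL in this assay; the other two sit at the limit of > 100 ug/mL in this assay, at which 2 of the 3 values shown sit. The readable steps are an at least 8.0-fold lower number from compound 1 to compound 2 (0.90 log units; beyond the scatter) and an at least 8.0-fold higher number from compound 2 to compound 3 (0.90 log units; beyond the scatter), while a step that the two limits leave unreadable from compound 1 to compound 3.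

Compound 4 `COc1ccc(-c2cc(-c3ccc(C(=O)N(C)C)cc3)cnc2N)cn1` differs from compound 3 by dimethylamino in place of amino on a carbonyl carbon. Within the data shown here, no measured step exchanges one amine for another on the carbonyl carbon; the only step on that carbon is an at least 8.0-fold higher number from compound 2 to compound 3 (0.90 log units; beyond the scatter), which says nothing about further substitution. Since compound 3 stands at a limit, only a drop would be readable. Compound 4 is expected to come in around 60 ug/mL, between 15 ug/mL and 100 ug/mL, which is estimated as an at least 1.6-fold lower number from compound 3 to compound 4 (0.22 log units; that floor lies within the scatter).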

Compound 4, solubility: > 100 ug/mL
Compound 4: no number, only a limit (the forecaster's own chance of this, stated with the estimate: 40%); middle value at least 1.6-fold (0.22 log units) from the limit.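

In this assay compound 4 gives > 100 ug/mL, which is a limit of the assay and not a number, so the steps to it from compound 1 and from compound 3 cannot be read. Dimethylamino in place of hydroxy on the carbonyl carbon gives an at least 8.0-fold higher number from compound 2 to compound 4 (0.90 log units; beyond the scatter), so the rise seen with amino at this place also appears with a group counted as having no hydrogen-bond donor. The upper end of the read-out now holds the sulfamoyl, carbamoyl and dimethylcarbamoyl compounds together: the limit of > 100 ug/mL in this assay, at which 3 of the 4 values shown sit.

From the compounds shown here alone, the order among compound 1, compound 3 and compound 4 stays open in this assay. Also open, going by these compounds, is how a methyl ester or a morpholine amide on the same carbonyl carbon would read there.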